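The source may report more compounds than this note shows. Statements on the series, on what has been measured and on what is new or still open speak of the compounds shown alone.

Working notes on a series of four compounds sharing one core, followed in a physicochemical assay for solubility, read by HPLC, using the shake flask method, measured as kinetic solubility, with a stated time of 20 h, at pH 6.5, tested at 200 uM; on this read-out higher numbers stand for higher solubility and lower numbers for lower solubility. Compound 1 `O=S(=O)(NCC1COC1)c1cccc(-c2ccc3nccc(-c4ccncc4)c3n2)c1` gives 20000 nM in this assay. Compound 2 `NS(=O)(=O)c1ccc(-c2ccc3nccc(-c4ccncc4)c3n2)cc1`, which carries a sulfamoyl group, gives 25000 nM in this assay. Compound 3 `c1cc(-c2ccnc3ccc(NC4CC4)nc23)ccn1` gives 90000 nM in this assay.

On these three numbers compound 2 stands second highest. Its nearest neighbour is compound 1, whose value lies within the scatter of it, so no order between the two can be read. Its furthest is compound 3, whose value lies beyond the scatter and is the higher of the pair.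

Compound 4 `O=S(=O)(NCCO)c1ccc(-c2ccc3nccc(-c4ccncc4)c3n2)cc1` has not yet been measured in this assay. It differs from compound 2 in one place: 2-hydroxyethyl in place of hydrogen on a sulfonamide nitrogen. Among the measured compounds shown here, no pair of measured compounds differing in a single place is available, so the size of this step has to be judged from the values as they stand. Compound 1, with a substituent on its sulfonamide nitrogen, and compound 2, with none, sit within the scatter of each other, which gives no sign that a change at that nitrogen carries the number far.

The step of no change at the digits printed from compound 2 to compound 4 (within the scatter) is expected to stay within the scatter, with no firm direction. Compound 4 is estimated at 25000 nM, with a range from 10000 nM to 60000 nM.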

Compound 4, solubility: 50000 nM
Estimate against measurement, compound 4: 2.0-fold (0.30 log units) below, and the stated range covers the measured number.
By their numbers in this assay, from the lowest: compounds 1, 2, 4 and 3 (each within the scatter of the next, the first and the last beyond it).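

In this assay, among the compounds shown here, 2-hydroxyethyl in place of hydrogen on a sulfonamide nitrogen gives a 2.0-fold higher number from compound 2 to compound 4 (0.30 log units; within the scatter), the first step between compounds that differ in only one place. At this position, the entering group, with its 3 heavy atoms, 1 hydrogen-bond donor and 1 hydrogen-bond acceptor, therefore leaves the read-out within the usual scatter, so no order can be read between the two compounds and no gain or loss can be assigned to the change. No accompanying measurement bears on what lies behind this step.

A single substituent leaves open whether other groups on the same sulfonamide nitrogen, such as a longer chain ending in an amine or a carboxylic acid, would also stay within the scatter or move the number beyond it. For the compounds shown here, it also remains open whether 2-hydroxyethyl in place of hydrogen would give a step of similar size on the arrangement found in compound 1, since the single step read here comes from one parent, compound 2.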